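Amino in Place of Chloro on the Core of Compound 2

The source may report more compounds than this note shows. Statements on the series, on what has been measured and on what is new or still open speak of the compounds shown alone.

Compound 1 `Nc1nn(C(=O)Nc2ccc(Cc3ccccc3)cc2)c2ccccc12` and compound 2 `Nc1nn(C(=O)Nc2ccc(Cc3ccccc3)cc2)c2ccc(Cl)cc12` share one core and differ only by a chloro group on an aromatic carbon. In a functional assay on LOX IMVI cells (Homo sapiens) for antiproliferative activity, read by sulforhodamine B assay, with a stated time of 48 h (on this read-out higher numbers stand for weaker inhibition of growth and lower numbers for stronger inhibition of growth), compound 1 gives 16100 nM, and compound 2 gives 18400 nM. The step of a 1.1-fold higher number from compound 1 to compound 2 (0.06 log units; within the scatter) lies within the scatter, so compound 2 holds the higher of the two numbers without being separated from compound 1 by more than repeated measurements would show. Compound 3 `Nc1ccc2c(c1)c(N)nn2C(=O)Nc1ccc(Cc2ccccc2)cc1` differs from compound 2 by amino in place of chloro on an aromatic carbon. Going by the values given here, the only measured step that bears on this, a 1.1-fold higher number from compound 1 to compound 2 (0.06 log units; within the scatter), also exchanged one small group on an aromatic carbon of the core and did not move the number beyond the scatter. A similarly small change is therefore expected for compound 3 in this assay, with no clear direction, so that a 1.2-fold lower number from compound 2 to compound 3 (0.06 log units; within the scatter) is the estimated step. Compound 3 is expected to give about 16000 nM, estimated between 6000 nM and 45000 nM.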

Compound 3, concentration for total growth inhibition: 16000 nM
Compound 3: the middle estimate sits on the measured number at the digits printed; low and high end bracket the measured number.
By their numbers in this assay, from the lowest: compounds 3, 1 and 2 (each within the scatter of the next).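

With compound 3, the position on the six-membered aromatic ring of carbon only now carries a third group, and the result in this assay extends what the chloro step showed. Amino in place of chloro gives a 1.2-fold lower number from compound 2 to compound 3 (0.06 log units; within the scatter), and amino in place of hydrogen gives a 1.0-fold lower number from compound 1 to compound 3 (0.00 log units; within the scatter), so neither replacement separates the compounds beyond the scatter. Across compounds 1, 2 and 3, this position therefore holds hydrogen, chloro or amino, the last bringing a hydrogen-bond donor and acceptor that chloro lacks, with no measurable separation in this read-out. No available evidence accounts for this flat result. The compounds shown leave open whether a carboxylic acid, a methoxy group or a longer chain on this same carbon would move the number beyond the scatter.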